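This account rests on a few compounds, and the source may have more. Where it says the series, first, only, none or still open, it means among the compounds named here.

Working notes on the series. Compound 1 `COC(=O)c1cc(Cl)ccc1OC(=O)COc1cc(O)c2c(=O)cc(-c3ccccc3)oc2c1` is the starting point for the step to compound 3. In an ADME assay on cells (T-cell, Mus musculus, strain BALB/c) for cytotoxicity, read by MTT assay, with a stated time of 48 h (a lower number here means that less compound is tolerated, a higher number that more compound is tolerated), compound 1 gives only a limit, > 436000 nM, and its position is simply that limit (the limit of > 436000 nM in this assay, at which 1 of the 2 values shown sits). Compound 2 `COC(=O)c1c(Br)cc(Br)cc1OC(=O)COc1cc(O)c2c(=O)cc(-c3ccccc3)oc2c1` belongs to the same set; in this assay compound 2 gives 398000 nM. The two values lie close together, both at the upper edge of what the assay resolves. Compound 3 `COC(=O)c1cc(O)ccc1OC(=O)COc1cc(O)c2c(=O)cc(-c3ccccc3)oc2c1` has not yet been measured. It differs from compound 1 by hydroxy in place of chloro on an aromatic carbon. Among the compounds with values here, no pair of measured compounds differing in one place exists here, so there is no measured step to compare against. The expectation for this assay is a step of no size beyond the scatter, with the reading most likely staying at the limit. Compound 3 is estimated at 450000 nM, expected between 200000 nM and 1000000 nM. The expected step is a step that the limit leaves unreadable from compound 1 to compound 3.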

Compound 3, half-maximal cytotoxic concentration: 263000 nM
Estimate against measurement, compound 3: 1.7-fold (0.23 log units) above; the range from low to high includes it.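

At the position para to a large group and meta to a methoxycarbonyl group, hydroxy gives a readable number rather than a limit: in this assay compound 3 gives 263000 nM. Hydroxy in place of chloro gives an at least 1.6-fold lower number from compound 1 to compound 3 (0.21 log units; that floor lies within the scatter), so this change is not established as going beyond the scatter. The true size of the step stays unknown because compound 1 rests on a limit: the limit of > 436000 nM in this assay, at which 1 of the 3 values shown sits.

The compounds shown leave open whether the drop in the number from chloro to hydroxy is real or only scatter around the upper edge of this assay. They also leave open whether an amine or a carboxylic acid at this same position would give a number like that of compound 3 or one that stays at a limit.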